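Replacing the aryl group on the amide of compound 3

The source may report more compounds than this note shows. Statements on the series, on what has been measured and on what is new or still open speak of the compounds shown alone.

Values so far in a functional assay on A2780 cells (Homo sapiens) for inhibition, read by sulforhodamine B assay, with a stated time of 3 days (on this read-out higher numbers stand for weaker inhibition and lower numbers for stronger inhibition), are:
- Compound 1 `O=C1Nc2ccc(F)cc2/C1=C\C(=O)c1ccc(C2CCCCC2)cc1` gives 2310 nM
- Compound 2 `O=C1Nc2ccc(F)cc2/C1=C\C(=O)c1cccs1` gives 2750 nM
- Compound 3 `COc1ccc(C(=O)Nc2ccc3c(c2)/C(=C/Nc2cccc(N4CCN(C)CC4)c2)C(=O)N3)cc1` gives 2050 nM

Compound 3 at 2050 nM lies within the usual scatter of both compound 1 and compound 2, so the three cannot be told apart on these numbers. Compound 4 `CN1CCN(c2cccc(N/C=C3\C(=O)Nc4ccc(NC(=O)c5ccc[nH]5)cc43)c2)CC1` carries one change from compound 3, namely 1H-pyrrol-2-yl in place of 4-methoxyphenyl on a carbonyl carbon with 1H-pyrrol-2-yl in place of 4-methoxyphenyl on a carbonyl carbon. Within the data shown here, no measured pair differs in one place, so the data offer no direct guide to this change. The expected 1.1-fold lower number from compound 3 to compound 4 (0.06 log units; within the scatter) is small, with no step beyond the scatter in this assay and no firm direction. Compound 4 is estimated at 1800 nM with an expected range from 500 nM to 5500 nM around it.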

Compound 4, half-maximal inhibitory concentration: 4460 nM
Compound 4: the middle estimate sits 2.5-fold (0.39 log units) below what was measured; measured number inside the range.
By their numbers in this assay, from the lowest: compounds 3, 1, 2 and 4 (each within the scatter of the next, the first and the last beyond it).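

In this assay the exchange of 4-methoxyphenyl for 1H-pyrrol-2-yl on a carbonyl carbon gives a 2.2-fold higher number from compound 3 to compound 4 (0.34 log units; beyond the scatter) and so a modest loss of inhibition. Among these compounds, this is the first sign that the group at this place matters, which the earlier compounds could not show. Nothing available explains the step.

On these data alone, it remains open whether the loss follows from removing the methoxy group, from the smaller ring or from the ring's hydrogen-bond donor. A plain phenyl or a 1-methyl-1H-pyrrol-2-yl group would help separate these.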